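The compounds below may be only part of what the source reports. "The series", "measured", "known", "first", "only" and "open" are said of these compounds alone.

Measured: compound 1 `CCn1c(C(=O)NCCN(C)C)ccc1C(CC)(CC)c1ccc(OCC(O)C(C)(C)C)c(C)c1`, 14 nM; compound 2 `CCn1c(C(=O)Nc2cccc(C(F)(F)F)c2)ccc1C(CC)(CC)c1ccc(OCC(O)C(C)(C)C)c(C)c1`, at the limit > 50000 nM.

In an assay on HL-60 cells for agonist activity at vitamin D3 receptor (Homo sapiens), read by microscopy, with a stated time of 96 h (on this read-out lower numbers stand for an effect already at smaller amounts and higher numbers for an effect only at larger amounts of compound), compound 1 gives 14 nM. Compound 2 reaches only the limit of this assay, > 50000 nM (the limit of > 50000 nM in this assay, at which 1 of the 2 values shown sits), and so sits at the weak end of the numbers shown. Going by the values given here, the change an at least 3500-fold higher number from compound 1 to compound 2 (3.55 log units; beyond the scatter) is the only measured step. Compound 3 `CCOC(=O)c1ccc(OC(=O)c2ccc(C(CC)(CC)c3ccc(OCC(O)C(C)(C)C)c(C)c3)n2CC)cc1` differs from compound 2 by 4-(ethoxycarbonyl)phenoxy in place of (3-(trifluoromethyl)phenyl)amino on a carbonyl carbon. Among the compounds with values here, no measured step covers an ester in this place, and compound 3 keeps an aryl group where compound 2 carries one, so the expected step of an at least 3.3-fold lower number from compound 2 to compound 3 (0.52 log units; beyond the scatter) is modest. Compound 3 is estimated at 15000 nM, within 1500 nM to 100000 nM.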

Compound 3, half-maximal effective concentration: > 50000 nM
Compound 3 gave a limit, no number (the forecaster's own chance of this, stated with the estimate: 45%); middle value at least 3.3-fold (0.52 log units) from the limit.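

In this assay compound 3 also reaches only a limit, not a number, so an ester on this carbonyl carbon ends where the anilide of compound 2 does: the limit of > 50000 nM in this assay, at which 2 of the 3 values shown sit. The step between compound 2 and compound 3 cannot be read, as both values are limits. Replacing (2-(dimethylamino)ethyl)amino with 4-(ethoxycarbonyl)phenoxy gives an at least 3500-fold higher number from compound 1 to compound 3 (3.55 log units; beyond the scatter), a second large step away from the value of compound 1.

Going by these compounds, it remains open whether the loss follows from the aromatic ring or from the missing dimethylamino group. A 2-hydroxyethyl chain or a 3-(dimethylamino)propyl chain on the amide nitrogen would bear on this.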